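This account rests on a few compounds, and the source may have more. Where it says the series, first, only, none or still open, it means among the compounds named here.

Measured so far:
compound 1 `COc1cc2c(cc1CC=C(C)C)C(=O)C[C@@H](c1ccc(Oc3cccc([N+](=O)[O-])c3)cc1)O2` — 21%
compound 2 `COc1ccc([C@@H]2C/C(=N/OCc3cn(-c4ccc(C#N)cc4)nn3)c3cc(CC=C(C)C)c(OC)cc3O2)cc1` — 50%

Compound 1 stands lowest of these two values in a functional assay on PC-3 cells (Homo sapiens) for inhibition, read by sulforhodamine B assay, with a stated time of 48 h, tested at 50 uM; a higher number here means more inhibition of growth at the concentration tested, a lower number less inhibition of growth; compound 2 sits well beyond the scatter above it. Compound 3 `CCCCOc1ccc([C@@H]2CC(=O)c3cc(CC=C(C)C)c(OC)cc3O2)cc1` has not been measured yet. It differs from compound 1 in one place: butyl in place of 3-nitrophenyl on an oxygen on an aromatic ring. Among the measured compounds shown here, no pair of measured compounds shows what such a swap alone does, so there is no direct guide for this change. The step of a number 6 percentage points higher from compound 1 to compound 3 (within the scatter) is expected to be small and upward, not beyond the usual scatter. Compound 3 is therefore estimated at 27%, with a range from 8% to 50%.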

Compound 3, percent growth inhibition at one concentration: 48%
Beside the measured number, compound 3's estimate is 21 percentage points below it, within the range that was stated.
By their numbers in this assay, from the lowest: compound 1; then compounds 3 and 2 (each within the scatter of the next).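

In this assay, among the compounds shown here, butyl in place of 3-nitrophenyl on an oxygen on an aromatic ring gives a number 27 percentage points higher from compound 1 to compound 3 (beyond the scatter) and is the first direct reading at this place. It shows that the group held on this oxygen matters, and that the aromatic 3-nitrophenyl ring can give way to an open butyl chain without a loss of growth inhibition. Nothing available explains this rise. This single step leaves open whether a longer hexyl chain or a butyl chain ending in an amine would change the reading further.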